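From 3-chlorophenyl to 4-chloropyridin-2-yl: one step, one number

This account rests on a few compounds, and the source may have more. Where it says the series, first, only, none or still open, it means among the compounds named here.

Compound 1 `COc1cc(C(=O)N2CCCC2)cc2nc(NCc3cccc(Cl)c3)oc12`: "not determined" (no result reported)
Compound 2 `COc1cc(C(=O)N2CCCC2(C)C)cc2nc(NCc3cccc(Cl)c3)oc12`: "not determined" (no result reported)
Compound 3 `COc1cc(C(=O)N2CCC(O)C(C)C2)cc2nc(NCc3cccc(Cl)c3)oc12`: 84 nm/s

Three compounds share one core, but only one of them has a result. In an ADME assay on Caco-2 cells (Homo sapiens) for permeability, read by LC-MS, in the apical to basolateral direction, with a stated time of 2 h (a higher number here means that the compound crosses the layer faster, a lower number that the compound crosses the layer more slowly), compound 3 gives 84 nm/s. Within the data shown here, this is the only number available, so compound 3 cannot be ranked against compound 1 or compound 2, and it serves as the sole reference point.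

The next compound to be tested is compound 4 `COc1cc(C(=O)N2CCC(O)C(C)C2)cc2nc(NCc3cc(Cl)ccn3)oc12`. It keeps the substituted amide of compound 3 and differs in one place: 4-chloropyridin-2-yl in place of 3-chlorophenyl on a saturated chain carbon bound to a nitrogen on an aromatic ring. In words, this is 4-chloropyridin-2-yl in place of 3-chlorophenyl on a saturated chain carbon bound to a nitrogen on an aromatic ring.

Among the measured compounds shown here, no pair of measured compounds shows what a single change does in this assay, so any expectation is weakly grounded. It starts from compound 3 at 84 nm/s and allows for a wide margin on either side. The expected change is a 1.2-fold lower number from compound 3 to compound 4 (0.08 log units; within the scatter), a small downward move that is not expected to go beyond the usual scatter. For compound 4 the estimated value is 70 nm/s, with an expected range from 25 nm/s to 170 nm/s.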

Compound 4, apparent permeability: 41 nm/s
Compound 4: the middle estimate sits 1.7-fold (0.23 log units) above what was measured; the measured number falls inside the stated range.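

In this assay, among these compounds, the change from 3-chlorophenyl to 4-chloropyridin-2-yl gives a 2.0-fold lower number from compound 3 to compound 4 (0.31 log units; beyond the scatter), so this position, on a saturated chain carbon bound to a nitrogen on an aromatic ring, now has the first step that can be read, and that step is a modest one. The two groups match in heavy-atom count and neither carries a net charge, while 4-chloropyridin-2-yl brings a ring nitrogen and a hydrogen-bond acceptor that 3-chlorophenyl lacks. Nothing measured here accounts for the step, so it stands as an observation without an explanation.

The two names differ both in the ring nitrogen and in where the chlorine is numbered, and this single pair cannot separate those two differences, nor can it show whether the step would carry over to the other amides of the series. From the compounds shown here alone, how a pyridin-2-yl group without chlorine or a 3-methoxyphenyl group would read at this place remains open, as does the effect of a carboxylic acid or an amine on the ring.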